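Swapping the Isoquinoline on a Triazole Hydroxamate

A few compounds are considered here, and "the series" means these few. Any claim that something is new, unique, unknown or untested is made for them only; others in the source may bear on it.

Measured so far:
compound 1 `O=C(NO)c1ccc(NCc2nc(-c3cccc4cnccc34)nn2-c2ccccc2)cc1` with 40.2%
compound 2 `Cc1cccc(-n2nc(-c3ccccc3)nc2CNc2ccc(C(=O)NO)cc2)c1` with 66%

In an assay on Sf9 cells for inhibition of protein deacetylase HDAC6 (Homo sapiens), read by fluorescence, with a stated time of 40 min, tested at 100 nM (on this read-out lower numbers stand for less inhibition and higher numbers for more inhibition at the one concentration tested (going by the name of the read-out)), compound 1 gives 40.2%, the lower of the two numbers measured; compound 2 lies higher by a margin beyond the scatter. Compound 3 `Cc1ccccc1-c1nc(CNc2ccc(C(=O)NO)cc2)n(-c2ccccc2)n1` has not been measured. It differs from compound 1 in one place: 2-methylphenyl in place of isoquinolin-5-yl on an aromatic carbon. For the measured compounds named here, no directly comparable step has been measured, so the size of the change is uncertain. Going by the values given here, a modest rise is expected, because compound 2 reads 66% as the only other compound without the isoquinoline. For compound 3 an inhibition of 55% is estimated, within 35% to 75%, which means an expected step of a number 14.8 percentage points higher from compound 1 to compound 3 (beyond the scatter).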

Compound 3, a percentage reported as inhibition, at one concentration (the size of the read-out at that concentration, not a potency): 53.2%
For compound 3 the middle estimate is 1.8 percentage points above the measured one; measured number inside the range.
By their numbers in this assay, from the lowest: compound 1; then compound 3; then compound 2.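

In this assay, 2-methylphenyl in place of isoquinolin-5-yl gives a number 13 percentage points higher from compound 1 to compound 3 (beyond the scatter), so this aromatic carbon of the core is sensitive to the group it carries. The second ring and the one hydrogen-bond acceptor of isoquinolin-5-yl are thus not needed here for inhibition at the one concentration tested. Nothing measured explains the step. From the compounds shown here alone, it remains open how much of the step belongs to the methyl group itself. Going by these compounds, it is also open how an amine or a carboxylic acid on this ring would read.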